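The source may hold more compounds than are shown below. What is called first, only, known or untested is meant among the compounds shown, and "the series" means these compounds.

Compound 1 `Nc1nc(O)c2c(n1)n(C1OC(CO)[C@@H](O)[C@H]1O)c(=O)n2CC(O)CSc1ccccc1` stands highest of the three numbers measured in a functional assay (B cells) with Mus musculus as the target (a higher number here means that more compound is needed for the effect, a lower number that less compound is needed), giving 142 uM. Compound 2 `C=CCn1c(=O)n(CCC(CCOCc2ccccc2)CCOCc2ccccc2)c2nc(N)nc(O)c21` gives 7 uM in this assay, and compound 3 `C=CCn1c(=O)n(C2OC(CO[Si](C)(C)C(C)(C)C)[C@@H](O)[C@H]2O)c2nc(N)nc(O)c21` gives 1 uM, both lower than compound 1 by amounts beyond the usual scatter. Compound 4 `Cn1c(=O)n(C2OC(CO)[C@@H](O)[C@H]2O)c2nc(N)nc(O)c21` has not yet been measured. It differs from compound 1 in one place: hydrogen in place of 1-hydroxy-2-(phenylsulfanyl)ethyl on a saturated chain carbon bound to an aromatic nitrogen. Going by the values given here, no measured pair shows this same change, so there is no directly comparable step to lean on. The three measured compounds all carry a larger group on that aromatic nitrogen, and compound 4 keeps only the methyl. The step from compound 1 to compound 4 is expected to be small or a slight rise, at a 1.4-fold higher number from compound 1 to compound 4 (0.15 log units; within the scatter). Compound 4 is estimated at 200 uM, with a likely range from 50 uM to 800 uM.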

Compound 4, concentration for half-maximal effect: 10 uM
Beside the measured number, compound 4's estimate is 20-fold (1.30 log units) above it, and the stated range ends above it.
By their numbers in this assay, from the lowest: compound 3; then compounds 2 and 4 (each within the scatter of the next); then compound 1.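

In this assay, replacing the 1-hydroxy-2-(phenylsulfanyl)ethyl group with hydrogen on the saturated chain carbon bound to an aromatic nitrogen gives a 14-fold lower number from compound 1 to compound 4 (1.15 log units; beyond the scatter). This position is therefore sensitive to what it carries, and the low number of compound 4 shows that the larger group is not required. Nothing here explains why the step is so large. Which part of the departing group accounts for the difference remains open: the phenyl ring, the sulfur or the hydroxyl. Going by these compounds, it is also open where an ethyl chain or an amine at this place would fall.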